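A Methyl Added on the Amide Aryl Ring

The source may report more compounds than this note shows. Statements on the series, on what has been measured and on what is new or still open speak of the compounds shown alone.

Measured compounds in a functional assay on the whole organism (strain Kunming) for inhibition, with Mus musculus as the target, in the writhing test, at a dose of 40 mg/kg by the oral route; a higher number here means more inhibition at the dose given (going by the name of the read-out), a lower number less inhibition:
compound 1, `CC(=O)Oc1ccc(-c2ccc(F)cc2F)cc1C(=O)Nc1ccccc1C`, 12.3%
compound 2, `CNC(=O)c1cc(-c2ccc(F)cc2F)ccc1OC(=O)c1ccccc1`, 47.5%
compound 3, `O=C(Oc1ccc(-c2ccc(F)cc2F)cc1C(=O)Nc1ccccc1)c1ccccc1`, 5.57%

Compound 3 gives the lowest of the three numbers in this assay. Its nearest neighbour is compound 1, whose number lies within the scatter of it, while compound 2 stands far above it, beyond the scatter.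

Compound 4, `Cc1ccccc1NC(=O)c1cc(-c2ccc(F)cc2F)ccc1OC(=O)c1ccccc1`, has not yet been measured. It differs from compound 3 in one place: methyl in place of hydrogen on an aromatic carbon. Among the compounds with values here, the only measured step, a number 41.9 percentage points lower from compound 2 to compound 3 (beyond the scatter), also concerns the group on the amide nitrogen, but it swaps phenyl for methyl, a much larger change than adding a single methyl. Compound 1, which carries the same 2-methylphenyl group on the amide nitrogen but an acetyl ester, gives a number within the scatter of compound 3. Taken together, this suggests a step from compound 3 to compound 4 that is expected to stay within the scatter, a number 4.4 percentage points higher from compound 3 to compound 4 (within the scatter). For compound 4, a value of about 10% is therefore estimated, with a range from 2% to 22%.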

Compound 4, a percentage reported as inhibition, in the whole organism at one dose (the size of the read-out at that dose, not a potency): 20.8%
For compound 4 the middle estimate is 10.8 percentage points below the measured one; the measured number falls inside the stated range.
By their numbers in this assay, from the lowest: compounds 3, 1 and 4 (each within the scatter of the next, the first and the last beyond it); then compound 2.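

Going from phenyl to 2-methylphenyl on the amide nitrogen adds only one carbon, yet in this assay it brings a number 15.2 percentage points higher from compound 3 to compound 4 (beyond the scatter), so a single methyl ortho to a large group on this ring can shift the read-out. The aryl group still does not match a plain methyl on that nitrogen, with a number 26.7 percentage points lower from compound 2 to compound 4 (beyond the scatter). With the 2-methylphenyl group held fixed, placing phenyl instead of methyl on the ester carbonyl carbon gives a number 8.5 percentage points higher from compound 1 to compound 4 (within the scatter), so no effect of that swap can be read here.

Nothing available explains the rise from the added methyl. As far as these compounds go, it also remains open whether a methoxy group, a chlorine atom or an ethyl group in place of this methyl would move the read-out the same way.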